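This account rests on a few compounds, and the source may have more. Where it says the series, first, only, none or still open, it means among the compounds named here.

Measured so far: compound 1 `CCC(C)(C)c1ccc2nc(N)sc2c1` with > 10 mg/kg; compound 2 `Nc1nc2cc(OC(F)(F)F)ccc2s1` with > 10 mg/kg; compound 3 `CN(C)S(=O)(=O)CCn1c(=N)sc2cc(OC(F)(F)F)ccc21` with > 10 mg/kg.

In a functional assay on the whole organism with Rattus norvegicus as the target (a higher number here means that more compound is needed for the effect, a lower number that less compound is needed), compound 1 gives > 10 mg/kg, which is a limit of the assay and not a number. Compound 2 likewise reaches only a limit, > 10 mg/kg. Compound 3 stands at the same limit, > 10 mg/kg, so that all three values shown sit together at the limit of > 10 mg/kg in this assay, at which 3 of the 3 values shown sit, and no numerical reading is known for any of them.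

Compound 4 `CSCCCn1c(=N)sc2cc(OC(F)(F)F)ccc21` differs from compound 3 in one place: (methylsulfanyl)methyl in place of dimethylsulfamoyl on a saturated chain carbon, two bonds along the chain from an aromatic nitrogen. Within the data shown here, no measured step is available to show how such a change moves this assay, so a step of any size or direction cannot be inferred. The step from compound 3 to compound 4 is expected to be a step that the limit leaves unreadable from compound 3 to compound 4, that is, none beyond the scatter. Compound 4 is expected to give about 12 mg/kg, within a range from 3 mg/kg to 40 mg/kg, and most likely to remain at a limit as well.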

Compound 4, dose for half-maximal effect: 4.2 mg/kg
The estimate for compound 4 lay 2.9-fold (0.46 log units) above the measured number; measured number inside the range.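

At this position, on a saturated chain carbon, two bonds along the chain from an aromatic nitrogen, the change from dimethylsulfamoyl to (methylsulfanyl)methyl gives an at least 2.3-fold lower number from compound 3 to compound 4 (0.37 log units; beyond the scatter) in this assay. This is the first reading shown that is a number and not a limit, so the group at this place can move the series off that limit. The full size of the step stays unknown because compound 3 itself reaches only a limit: the limit of > 10 mg/kg in this assay, at which 3 of the 4 values shown sit.

The compounds shown do not separate the loss of dimethylsulfamoyl from the gain of (methylsulfanyl)methyl. Going by these compounds, how an amine, a carboxylic acid or a longer chain would read at this place also stays open.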